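The compounds below may be only part of what the source reports. "The series", "measured", "known", "first", "only" and "open" are said of these compounds alone.

Measured compounds:
Compound 1 `COc1cc(OC)c2c(=O)cc(C(=O)Nc3ccc(Oc4ccc([N+](=O)[O-])cc4)cc3)[nH]c2c1` gives > 22900 nM in an ADME assay on BJ cells (Homo sapiens) for antiproliferative activity, with a stated time of 72 h (a higher number here means that more compound is needed for the effect, a lower number that less compound is needed), a limit of the assay.
Compound 2 `COC(=O)c1cc(=O)c2cc(NC(=O)Nc3ccc(Cl)c(C(F)(F)F)c3)ccc2[nH]1` gives > 12600 nM in this assay, a limit.
Compound 3 `COC(=O)c1cc(=O)c2cc(NC(=O)Nc3ccc(Cl)c(Cl)c3)ccc2[nH]1` gives > 12600 nM in this assay, a limit.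

Compound 3 thus sits at the limit of > 12600 nM in this assay, at which 2 of the 3 values shown sit, the same limit as compound 2, while compound 1 sits at the limit of > 22900 nM in this assay, at which 1 of the 3 values shown sits; none of the three values is a number. Compound 4 `COC(=O)c1cc(=O)c2cc(NC(=O)Nc3ccc(F)c(Cl)c3)ccc2[nH]1` differs from compound 3 in one place: fluoro in place of chloro on an aromatic carbon. For the measured compounds named here, the only measured step of a related kind, a step that the two limits leave unreadable from compound 2 to compound 3, cannot be sized, so nothing in these data shows how this fluoro for chloro swap moves the read-out. Compound 4 is therefore expected to stay near the limit, with a step that the limit leaves unreadable from compound 3 to compound 4 meaning no readable change. Compound 4 is estimated at 20000 nM, within 8000 nM to 60000 nM.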

Compound 4, half-maximal effective concentration: > 12600 nM
Compound 4: no number, only a limit; the forecaster's own chance of this, stated with the estimate: 80%; the middle value does not contradict the limit.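

Compound 3 and compound 4 each give only a limit in this assay, and the step between them cannot be read. Going by these compounds, whether fluoro in place of chloro changes the read-out at all stays open.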